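The source may hold more compounds than are shown below. What is called first, only, known or untested is meant among the compounds shown, and "the series" means these compounds.

Three close relatives built on one shared core have been followed in an ADME assay (liver) for pharmacokinetics, with Liver microsome (Rattus norvegicus) as the target, using microsomes; a higher number here means that the compound lasts longer, a lower number that the compound disappears faster. Compound 1 `CCOC(=O)/C=C/c1ccc(NC(=O)C2(NC(=O)c3ccc4c(C5CCCC5)c(-c5ncc(Cl)cn5)n(C)c4c3)CCC2)cc1OCC` gives 3.07 h. Compound 2 `CCOc1cc(NC(=O)C2(NC(=O)c3ccc4c(C5CCCC5)c(-c5ncc(Cl)cn5)n(C)c4c3)CCC2)ccc1/C=C/C(=O)OCC(Cl)(Cl)Cl` gives 0.233 h, the lowest of the three numbers, and compound 3 `CCOc1cc(NC(=O)C2(NC(=O)c3ccc4c(C5CCCC5)c(-c5ncc(Cl)cn5)n(C)c4c3)CCC2)ccc1/C=C/C(=O)OCCOc1ccccc1` gives 16.5 h. Compound 4 `CCOc1cc(NC(=O)C2(NC(=O)c3ccc4c(C5CCCC5)c(-c5ncc(Cl)cn5)n(C)c4c3)CCC2)ccc1/C=C/C(=O)OCC(=O)N1CCOCC1` has not yet been measured in this assay. It differs from compound 2 at a single spot: (morpholin-4-yl)carbonyl in place of trichloromethyl on a saturated chain carbon bound to an oxygen next to a carbonyl group. Read one bond further out, a 2,2,2-trichloroethoxy group becomes a ((morpholin-4-yl)carbonyl)methoxy group.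

Going by the values given here, two measured steps bear on this change, both at the same spot. Moving from methyl to trichloromethyl gave a 13-fold lower number from compound 1 to compound 2 (1.12 log units; beyond the scatter), and moving from trichloromethyl to phenoxymethyl gave a 71-fold higher number from compound 2 to compound 3 (1.85 log units; beyond the scatter). In both comparisons the trichloromethyl compound sits far below its partner, so a clear rise in this assay is expected for compound 4, though its size is uncertain because the incoming group resembles neither of the groups already tried. Compound 4 is therefore expected to reach about 3 h, within 0.8 h to 12 h, an expected step of a 13-fold higher number from compound 2 to compound 4 (1.11 log units; beyond the scatter).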

Compound 4, half-life: 0.733 h
Compound 4: the middle estimate sits 4.1-fold (0.61 log units) above what was measured; the whole stated range lies above it.
By their numbers in this assay, from the lowest: compound 2; then compound 4; then compound 1; then compound 3.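

In this assay, (morpholin-4-yl)carbonyl in place of trichloromethyl gives only a modest rise (a 3.1-fold higher number from compound 2 to compound 4 (0.50 log units; beyond the scatter)), far short of what phenoxymethyl gives at this spot. The new group also falls well behind phenoxymethyl (a 23-fold lower number from compound 3 to compound 4 (1.35 log units; beyond the scatter)) and behind plain methyl (a 4.2-fold lower number from compound 1 to compound 4 (0.62 log units; beyond the scatter)), so a ring in this group does not by itself give a long half-life: phenoxymethyl and (morpholin-4-yl)carbonyl both hold one, yet their compounds lie far apart. Nothing available here offers a reason for this order.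

Going by these compounds, it remains open whether the morpholine ring or the carbonyl group that joins it holds the number down. A dimethylamino group on that carbonyl, or a phenyl group in place of phenoxymethyl, would show where such close variants rank in this series.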